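Series notes: fluoro for methyl on one aryl ring

The compounds below may be only part of what the source reports. "The series", "measured", "known", "first", "only" and "open" are said of these compounds alone.

Measured compounds:
- compound 1 `Cc1ccc(/C=C2\CCC/C(=C\c3ccccc3[N+](=O)[O-])C2=O)cc1`: 4.86 in a physicochemical assay for lipophilicity; a lower number here means a more polar compound, a higher number a more lipophilic compound
- compound 2 `Cc1ccc(/C=C2\CCC/C(=C\c3ccc([N+](=O)[O-])cc3)C2=O)cc1`: 5.08 in this assay
- compound 3 `O=C1/C(=C/c2ccc(F)cc2)CCC/C1=C\c1cccc([N+](=O)[O-])c1`: 5.06 in this assay

Compound 2 gives the highest of the three numbers in this assay; compound 3 lies closest to it and compound 1 furthest, yet both gaps fall within the scatter, so no order among the three can be read. Compound 4 `O=C1/C(=C/c2ccc(F)cc2)CCC/C1=C\c1ccc([N+](=O)[O-])cc1` has not been measured; it differs from compound 2 by fluoro in place of methyl on an aromatic carbon. Among the measured compounds shown here, no measured pair shows this change on its own, so the step has to be judged from the change itself: a small decrease in this assay is expected, near the edge of the scatter. The step from compound 2 to compound 4 is expected at a number 0.33 log units lower from compound 2 to compound 4 (beyond the scatter). Compound 4 is therefore expected at 4.75, within 4.45 to 5.05.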

Compound 4, partition coefficient: 5.08
Compound 4: middle estimate off by 0.33 log units, on the low side, outside the stated range (above it).
By their numbers in this assay, from the lowest: compounds 1, 3, 2 and 4 (each within the scatter of the next).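

In this assay, among the compounds shown here, fluoro in place of methyl on an aromatic carbon, para to a large group, gives no change at the digits printed from compound 2 to compound 4 (within the scatter) in the first pair of the series that differs in one place. The 4-methylphenyl to 4-fluorophenyl change therefore leaves this read-out unmoved here, with the rest of compound 2 held fixed. No measurement bears on why the two groups read alike.

Still open, as far as these compounds go, is whether an amine, a carboxylic acid or a longer chain at this position would shift the number. Also open, from the compounds shown here alone, is whether the same change reads alike with the nitro group elsewhere on its ring.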